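The compounds below may be only part of what the source reports. "The series", "measured", "known", "first", "only" and "open" are said of these compounds alone.

Working notes on the series. The shared core carries an amine nitrogen on a double-bonded ring carbon, and the substituent on that nitrogen is what varies. In a functional assay on MGC-803 cells (Homo sapiens) for inhibition, read by sulforhodamine B assay (on this read-out lower numbers stand for stronger inhibition and higher numbers for weaker inhibition), compound 1 `COc1cccc(NC2=CC(=O)c3nc4n(c3C2=O)[C@H]2OC[C@@H](O)[C@H]2OC4)c1` gives 1780 nM. Compound 2 `COc1ccccc1NC1=CC(=O)c2c(nc3n2[C@H]2OC[C@@H](O)[C@H]2OC3)C1=O` gives 1670 nM in this assay; of the two numbers shown, the one for compound 1 is the higher, but the gap to compound 2 is within the scatter, so the two read as the same. Compound 3 `O=C1C(NC2CCCC2)=CC(=O)c2c1nc1n2[C@H]2OC[C@@H](O)[C@H]2OC1` is reported in this assay only as a limit, > 16000 nM; this is the limit described by the limit of > 16000 nM in this assay, at which 1 of the 3 values shown sits. Among the compounds with values here, the single measured step, an at least 9.5-fold higher number from compound 2 to compound 3 (0.98 log units; beyond the scatter), is the cyclopentyl-for-aryl exchange.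

Compound 4 `COc1ccc(NC2=CC(=O)c3nc4n(c3C2=O)[C@H]2OC[C@@H](O)[C@H]2OC4)cc1` is not yet measured. It differs from compound 1 by 4-methoxyphenyl in place of 3-methoxyphenyl on an amine nitrogen. Within the data shown here, no measured step moves the methoxy around the aromatic ring; the only step available swaps the aromatic group for a saturated one, which does not bear on this change, and the two aryl-bearing compounds 1 and 2 sit together. The step of a 1.0-fold higher number from compound 1 to compound 4 (0.00 log units; within the scatter) is therefore expected to stay within the scatter, with no direction. The estimate for compound 4 in this assay is 1800 nM, within 700 nM to 4600 nM.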

Compound 4, half-maximal inhibitory concentration: 1680 nM
Beside the measured number, compound 4's estimate is 1.1-fold (0.03 log units) above it; low and high end bracket the measured number.
By their numbers in this assay, from the lowest: compounds 2, 4 and 1 (each within the scatter of the next). At a limit, above all of these: compound 3.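

Within the data shown here, the exchange of 3-methoxyphenyl for 4-methoxyphenyl on the amine nitrogen gives a 1.1-fold lower number from compound 1 to compound 4 (0.03 log units; within the scatter) in this assay and is the only measured step that moves the methoxy group while keeping the aromatic ring. Compounds 1, 2 and 4 all lie within the scatter of one another, so among these three the place of the methoxy group on the aromatic ring does not register, and the only step at this position beyond the scatter remains an at least 9.5-fold higher number from compound 2 to compound 3 (0.98 log units; beyond the scatter) with the cyclopentyl group. Nothing in the information at hand accounts for this flat result.

Still open, as far as these compounds go, is whether substituents other than methoxy on the aromatic ring, such as a chlorine, a hydroxyl or a dimethylamino group, or the plain phenyl group, would stay at the level of these three compounds. Also open, from the compounds shown here alone, is whether the weaker result with cyclopentyl extends to other non-aromatic groups, and where a benzyl group or a longer chain such as n-butyl on the amine nitrogen would fall.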